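Fluoro in place of methoxy in the series

The source may report more compounds than this note shows. Statements on the series, on what has been measured and on what is new or still open speak of the compounds shown alone.

Among the measured compounds shown here, compound 2 `COc1ccc(OCc2ccc(C(=O)Nc3ccccc3N)cc2)cc1` gives 3480 nM in a functional assay on MGC-803 cells (Homo sapiens) for antiproliferative activity, read by CCK-8 assay, with a stated time of 72 h (on this read-out higher numbers stand for weaker inhibition and lower numbers for stronger inhibition), and holds the only actual number so far. Compound 1 `Nc1ccccc1NC(=O)c1ccc(COc2ccc([N+](=O)[O-])cc2)cc1` gives > 32000 nM in this assay as a limit of the assay and not a number. Compound 3 `Nc1ccccc1NC(=O)c1ccc(COc2ccc(F)cc2)cc1` departs from compound 2 by fluoro in place of methoxy on an aromatic carbon in one place, fluoro in place of methoxy on an aromatic carbon. For the measured compounds named here, the one measured step at that place is an at least 9.1-fold lower number from compound 1 to compound 2 (0.96 log units; beyond the scatter) for methoxy in place of nitro, so the group there matters. A smaller move toward weaker inhibition is expected, with a 2.3-fold higher number from compound 2 to compound 3 (0.36 log units; beyond the scatter) as the estimated step. For compound 3 the estimated value in this assay is 8000 nM with 2500 nM to 25000 nM as its range.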

Compound 3, half-maximal inhibitory concentration: 4970 nM
Compound 3: middle estimate off by 1.6-fold (0.21 log units), on the high side; the measured number falls inside the stated range.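

Fluoro and methoxy read alike at this position, with a 1.4-fold higher number from compound 2 to compound 3 (0.15 log units; within the scatter), so this change does not separate the two groups. The nitro group stands apart, with an at least 6.4-fold lower number from compound 1 to compound 3 (0.80 log units; beyond the scatter), so the gap first seen against compound 2 holds for a second group. The value of compound 1 is a limit of the assay and not a number, so the full size of that gap stays unknown: the limit of > 32000 nM in this assay, at which 1 of the 3 values shown sits.

Open, from the compounds shown here alone, is whether an amine, a carboxylic acid or a longer chain here reads like fluoro and methoxy or like nitro. The compounds shown also leave open how the unsubstituted phenyl reads.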